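Methyl in Place of Methoxy on the Fused Ring

The source may report more compounds than this note shows. Statements on the series, on what has been measured and on what is new or still open speak of the compounds shown alone.

All three measured compounds were tested in a functional assay on SK-OV-3 cells (Homo sapiens) for antiproliferative activity, read by MTT assay, with a stated time of 72 h; on this read-out lower numbers stand for stronger inhibition and higher numbers for weaker inhibition. Compound 1 `O=S(=O)(c1ccc(-c2cnc(C3CC3)o2)cc1)N1CCCOc2ccccc21` gives 36 nM. Compound 2 `O=S(=O)(c1ccc(-c2cnc(C3CC3)o2)cc1)N1CCCOc2ccc(F)cc21` gives 15 nM. Compound 3 `COc1ccc2c(c1)N(S(=O)(=O)c1ccc(-c3cnc(C4CC4)o3)cc1)CCCO2` gives 53 nM.

Compound 3 has the highest number of the three. Its nearest neighbour is compound 1, with a 1.5-fold higher number from compound 1 to compound 3 (0.17 log units; within the scatter), a gap within the scatter. Its furthest is compound 2, with a 3.5-fold higher number from compound 2 to compound 3 (0.55 log units; beyond the scatter), a gap beyond the scatter. For comparison, the change from compound 1 to compound 2 gave a 2.4-fold lower number from compound 1 to compound 2 (0.38 log units; beyond the scatter).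

Compound 4 `Cc1ccc2c(c1)N(S(=O)(=O)c1ccc(-c3cnc(C4CC4)o3)cc1)CCCO2` differs from compound 3 in one place: methyl in place of methoxy on an aromatic carbon. For the measured compounds named here, no measured step involves a methyl group, so the only guidance comes from the steps into compound 3, which show that adding methoxy in place of hydrogen left the number within the scatter, while the small fluoro substituent gave the lowest number. Removing one oxygen while keeping a single carbon is expected to shift the number little, perhaps slightly downward. Compound 4 is therefore expected to give 40 nM, within a range of 15 nM to 110 nM, corresponding to an estimated step of a 1.3-fold lower number from compound 3 to compound 4 (0.12 log units; within the scatter).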

Compound 4, half-maximal inhibitory concentration: 34 nM
Beside the measured number, compound 4's estimate is 1.2-fold (0.07 log units) above it; the range from low to high includes it.
By their numbers in this assay, from the lowest: compound 2; then compounds 4, 1 and 3 (each within the scatter of the next).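

Methyl at this position gives a result much like hydrogen and methoxy, with a 1.1-fold lower number from compound 1 to compound 4 (0.02 log units; within the scatter) and a 1.6-fold lower number from compound 3 to compound 4 (0.19 log units; within the scatter) as the steps that link these three groups. Fluoro is the only one of the four groups that stands apart, with a 2.3-fold higher number from compound 2 to compound 4 (0.36 log units; beyond the scatter) adding a third step beyond the scatter from compound 2 to each of the other compounds. Nothing at hand gives a reason for this difference between fluoro and the other groups.

Going by these compounds, whether the low number belongs to fluoro alone or also extends to another halogen such as chloro remains open. So does the effect of an amine or a carboxylic acid at this place, and of any of these groups on the other aromatic carbons of the same ring.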